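The source may hold more compounds than are shown below. What is called first, only, known or untested is meant among the compounds shown, and "the series" means these compounds.

The measured compounds and their readings:

Compound 1 `c1ccc(Oc2ccc3c(NCCCNCc4ccco4)ccnc3c2)cc1` gives 9.28 in a physicochemical assay for acid dissociation.
Compound 2 `c1ccc(Cc2ccc3c(NCCCNCc4ccco4)ccnc3c2)cc1` gives 9.47 in this assay.
Compound 3 `Clc1ccc(Oc2ccc3c(NCCCNCc4ccco4)ccnc3c2)cc1` gives 9.28 in this assay.

Compound 3 stands level with compound 1, the two reading the same at the digits reported, as the step of no change at the digits printed from compound 1 to compound 3 (within the scatter) shows. The other measured compound lies only slightly apart: the step of a number 0.19 log units lower from compound 2 to compound 3 (within the scatter) stays within the scatter, so no ordering among the three can be claimed.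

The unmeasured compound 4 `c1coc(CNCCCNc2ccnc3cc(-c4cccc5ccccc45)ccc23)c1` differs from compound 3 in one place: naphthalen-1-yl in place of 4-chlorophenoxy on an aromatic carbon. Two of the measured steps bear on this change. The step of a number 0.19 log units higher from compound 1 to compound 2 (within the scatter) replaced the ether link with a carbon link at the same position and moved the reading only within the scatter, and the step of no change at the digits printed from compound 1 to compound 3 (within the scatter) altered the distal aromatic ring without any change at the digits reported. Among the compounds with values here, every variation so far at this position has left this assay essentially where it was. Compound 4 is therefore expected to sit close to compound 3, with the step of a number 0.02 log units higher from compound 3 to compound 4 (within the scatter) expected to fall within the scatter. Compound 4 is estimated at 9.3, between 8.9 and 9.7.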

Compound 4, acid dissociation constant: 9.47
The estimate for compound 4 lay 0.17 log units below the measured number, and the stated range covers the measured number.
By their numbers in this assay, from the lowest: compounds 1, 3, 2 and 4 (each within the scatter of the next).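

Taking out 4-chlorophenoxy and putting in naphthalen-1-yl, with 2 six-membered aromatic rings of carbon only in place of one and with the oxygen and chlorine gone, gives a number 0.19 log units higher from compound 3 to compound 4 (within the scatter) in this assay for this position on the shared core. Set against benzyl and phenoxy, the same group gives no change at the digits printed from compound 2 to compound 4 (within the scatter) and a number 0.19 log units higher from compound 1 to compound 4 (within the scatter) and so none of the three exchanges stands out from the scatter. The earlier compounds had varied only a single aromatic ring held through one linking atom, whereas compound 4 shows that among these four compounds a directly attached group of two fused rings, carrying only carbon, also leaves this assay without any step beyond the scatter.

Going by these compounds, whether an amine, a carboxylic acid or a longer chain at this position on an aromatic carbon would stay equally close to these readings remains open. The data offered here also give no measurement that could account for how closely these readings agree.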